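Octylcarbonyl on the ring nitrogen of a hydroxyphenyl amide

This account rests on a few compounds, and the source may have more. Where it says the series, first, only, none or still open, it means among the compounds named here.

Measured compounds:
compound 1, `CCCCCCCCC(=O)N1c2ccccc2CCC1C(=O)Nc1ccccc1C(F)(F)F`: 4320 nM
compound 2, `O=C(Nc1ccccc1)C1CCc2ccccc2N1`: 110000 nM
compound 3, `O=C(Nc1ccccc1O)C1CCc2ccccc2N1`: 4310 nM

In a functional assay on PC-3 cells (Homo sapiens) for cytotoxicity, read by sulforhodamine B assay, with a stated time of 72 h (a lower number here means a stronger inhibitor of growth, a higher number a weaker inhibitor of growth), compound 3 gives the lowest of the three numbers, but compound 1 gives a value that cannot be told apart from it, so the two stand level. Among the measured compounds shown here, compound 2 sits far higher; the only single-point step in the set, a 26-fold lower number from compound 2 to compound 3 (1.41 log units; beyond the scatter), is large and concerns the hydroxy group, not the ring nitrogen.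

Compound 4, `CCCCCCCCC(=O)N1c2ccccc2CCC1C(=O)Nc1ccccc1O`, is not yet measured. It differs from compound 3 in one place: octylcarbonyl in place of hydrogen on a nitrogen on an aromatic ring in a ring. For the measured compounds named here, no measured pair isolates this change. Compound 1 carries the same octylcarbonyl group but also a trifluoromethyl in place of the hydroxy, so its value and that of compound 3 show only that the two substitution patterns together land at the same number. Going by the values given here, with no direct precedent, the expected step of a 1.2-fold lower number from compound 3 to compound 4 (0.09 log units; within the scatter) is small, not beyond the scatter. Compound 4 is therefore estimated at 3500 nM, with a range from 1200 nM to 10000 nM.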

Compound 4, concentration for 50% growth inhibition: 45200 nM
Compound 4: the middle estimate sits 13-fold (1.11 log units) below what was measured; measured number above the stated range.
By their numbers in this assay, from the lowest: compounds 3 and 1 (each within the scatter of the next); then compound 4; then compound 2.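

In this assay, octylcarbonyl in place of hydrogen on the nitrogen of the shared core proves to be no silent change when the hydroxy group is present, giving a 10-fold higher number from compound 3 to compound 4 (1.02 log units; beyond the scatter). With octylcarbonyl kept on that nitrogen, hydroxy in place of trifluoromethyl on an aromatic carbon gives a 10-fold higher number from compound 1 to compound 4 (1.02 log units; beyond the scatter), so the level values of compound 1 and compound 3 conceal two large steps that run in the same direction towards compound 4. Nothing among the available data explains either step.

The compounds shown leave open whether a shorter acyl group such as acetyl on that nitrogen would give a step of the same size as octylcarbonyl. They also leave open how trifluoromethyl on the aromatic carbon would read with hydrogen on that nitrogen, which would separate the two changes further.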